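The source may hold more compounds than are shown below. What is called first, only, known or untested is meant among the compounds shown, and "the series" means these compounds.

Measured so far:
Compound 1 `CC(C)c1ccc(N2C(=O)C=CC2OCC(F)(F)F)cc1`: 9570 nM
Compound 2 `CCc1ccc(N2C(=O)C=CC2OCC(F)(F)F)cc1`: 8090 nM
Compound 3 `O=C1C=CC(OCC(F)(F)F)N1c1ccc([N+](=O)[O-])cc1`: 3270 nM

In a functional assay on A549 cells (Homo sapiens) for inhibition (on this read-out lower numbers stand for stronger inhibition and higher numbers for weaker inhibition), compound 1 gives 9570 nM, at the upper end of this small set. It is not separated from compound 2, since the step between them is a 1.2-fold lower number from compound 1 to compound 2 (0.07 log units; within the scatter). Only compound 3 stands clearly apart from it.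

The compound still to be measured is compound 4 `COC(=O)c1ccc(N2C(=O)C=CC2OCC(F)(F)F)cc1`, which shares the core of compound 1. The change is methoxycarbonyl in place of isopropyl on an aromatic carbon.

For the measured compounds named here, no measured compound carries methoxycarbonyl, so the evidence is indirect. Going by the values given here, the nearest precedent is nitro in place of isopropyl on an aromatic carbon, which gave a 2.9-fold lower number from compound 1 to compound 3 (0.47 log units; beyond the scatter). The matching replacement of ethyl gave a 2.5-fold lower number from compound 2 to compound 3 (0.39 log units; beyond the scatter), a step of similar size. Shortening the chain, by contrast, gave a step within the scatter. Both replacements of a saturated chain by nitro lowered the number modestly, so a modest drop is expected here too, though nitro is only a loose guide to methoxycarbonyl. The expected change is a 2.1-fold lower number from compound 1 to compound 4 (0.33 log units; beyond the scatter). For compound 4 the estimated value is 4500 nM, with an expected range from 2000 nM to 9500 nM.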

Compound 4, half-maximal inhibitory concentration: 8170 nM
The estimate for compound 4 lay 1.8-fold (0.26 log units) below the measured number, within the range that was stated.
By their numbers in this assay, from the lowest: compound 3; then compounds 2, 4 and 1 (each within the scatter of the next).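

In this assay methoxycarbonyl in place of isopropyl on this aromatic carbon, para to a large group, gives a step within the scatter (a 1.2-fold lower number from compound 1 to compound 4 (0.07 log units; within the scatter)), and the comparison with ethyl gives the same reading (a 1.0-fold higher number from compound 2 to compound 4 (0.00 log units; within the scatter)). Methoxycarbonyl in place of nitro, by contrast, is a step beyond the scatter (a 2.5-fold higher number from compound 3 to compound 4 (0.40 log units; beyond the scatter)), so the drop seen with nitro is not shared by every replacement of a saturated chain at this position, and compound 4 goes against that earlier trend, leaving compound 3 alone apart from the other three. No measurement is available that would explain why nitro and methoxycarbonyl part here.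

Going by these compounds, what remains open is whether the lower number belongs to nitro alone or would also appear with a nitrile, a carboxylic acid or an amine on this aromatic carbon. All four compounds also keep the rest of the shared core unchanged, so they say nothing about how a longer chain at this position, or a change elsewhere in the molecule, would read in this assay.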